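The compounds below may be only part of what the source reports. "The series", "measured", "known", "first", "only" and "open" are said of these compounds alone.

Measured so far:
compound 1 `COc1ccc(-c2ccc(CN(CCC3CCN(Cc4ccc(C)cc4)CC3)C(=O)NC(C)C)cc2)cc1` — 91.5%
compound 2 `Cc1ccc(CN2CCC(CCN(Cc3ccc(-c4cccc(C#N)c4)cc3)C(=O)NC(C)C)CC2)cc1` — 97%

In an in vitro functional assay on HEK293 cells for antagonist activity at melanin-concentrating hormone receptor 1 (Homo sapiens) (on this read-out lower numbers stand for smaller maximal responses and higher numbers for larger maximal responses), compound 2 stands highest of the two numbers, with compound 1 nearest at a number 5.5 percentage points higher from compound 1 to compound 2 (within the scatter). Compound 3 `Cc1ccc(CN2CCC(CCN(Cc3ccc(-c4cccc(C#N)c4)cc3)C(=O)NC(C)(C)CO)CC2)cc1` differs from compound 2 by hydroxymethyl in place of hydrogen on a saturated chain carbon bound to an amide-type nitrogen and two saturated chain carbons. Going by the values given here, no measured step touches this part of the structure; the one step known, from a change on an aromatic carbon, was within the scatter. With nothing pointing elsewhere, compound 3 is expected to show no step beyond the scatter, a number 2 percentage points lower from compound 2 to compound 3 (within the scatter), and its estimated value is 95% within 82% to 105%.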

Compound 3, largest response reached (reported as Imax), in percent of the reference or control that the assay uses: 99.3%
The estimate for compound 3 lay 4.3 percentage points below the measured number; the range from low to high includes it.
By their numbers in this assay, from the lowest: compounds 1, 2 and 3 (each within the scatter of the next).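

Hydroxymethyl on this saturated chain carbon, which turns isopropyl into 1-(hydroxymethyl)-1-methylethyl, gives in this assay a number 2.3 percentage points higher from compound 2 to compound 3 (within the scatter), so the maximal response is kept with this larger group in place. The earlier compounds shown here differed only on an aromatic carbon and showed nothing about this end of the molecule. Nothing at hand accounts for this result. Going by these compounds, it remains open whether a carboxylic acid, an amine or a longer chain ending in hydroxyl at this carbon would keep the response in this assay as well.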